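The compounds below may be only part of what the source reports. "The series", "measured", "known", "first", "only" and "open" are said of these compounds alone.

In an ADME assay on microsomes (Homo sapiens) for metabolic stability (on this read-out higher numbers stand for a longer-lived compound and lower numbers for a shorter-lived compound), compound 1 `Cc1ccc(C2CC=NN2C(=O)C(C)(C)C)cc1` gives 0.367 h. Compound 2 `O=C(c1cnco1)N1CCC(C(=O)N2N=CC[C@H]2c2ccccc2)CC1` gives > 3 h in this assay, which is a limit of the assay and not a number, so it stands at the limit of > 3 h in this assay, at which 1 of the 2 values shown sits. Compound 1 differs from compound 2 in more than one place, so the pair offers no clean comparison. Compound 3 `O=C(c1cscn1)N1CCC(C(=O)N2N=CC[C@H]2c2ccccc2)CC1` keeps the rest of compound 2 and changes a single group: 1,3-thiazol-4-yl in place of 1,3-oxazol-5-yl on a carbonyl carbon. In words, it carries 1,3-thiazol-4-yl in place of 1,3-oxazol-5-yl on a carbonyl carbon. Within the data shown here, no measured pair shows this swap, so the data give no direction, and no change beyond the usual scatter is expected in this assay. The expected step is a number no higher from compound 2 to compound 3 (the limit leaves the size open). For compound 3 the estimated half-life is 3 h, with an expected range from 1.2 h to 6 h.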

Compound 3, half-life: > 3 h
Compound 3 ended at the assay's limit; the forecaster's own chance of this, stated with the estimate: 50%; the middle value lies on the limit itself.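

Among these compounds, compound 2 and compound 3 both ended at a limit of this assay and not at a number, so no step between them can be read: the limit of > 3 h in this assay, at which 2 of the 3 values shown sit. The compounds shown leave open how far either half-life extends past that limit, and whether 1,3-thiazol-4-yl and 1,3-oxazol-5-yl differ at all on this read-out.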